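The source may report more compounds than this note shows. Statements on the series, on what has been measured and on what is new or still open speak of the compounds shown alone.

Working notes on the series. In an ADME assay on microsomes from liver (Homo sapiens) for metabolic stability, read by LC-MS, with a stated time of 10 min (a lower number here means that less of the compound is left, a higher number that more of the compound is left), compound 1 (`C[C@@H]1CN(c2cccc3c2C[C@H](CN(C)[C@H]2CCCc4cccnc42)NC3)C[C@H](C)N1`) reads 100% and compound 2 (`CC(C)N1CCN(c2cccc3c2C[C@H](CN(C)[C@H]2CCCc4cccnc42)NC3)CC1`) reads 56.6% while compound 3 (`FC1(F)CCC(CN(C[C@H]2Cc3c(cccc3N3CCNCC3)CN2)[C@H]2CCCc3cccnc32)CC1`) reads 68.6% and so takes the second highest place of the three. Within the data shown here, the next structure is compound 4 (`CCCN(C[C@H]1Cc2c(cccc2N2CCNCC2)CN1)[C@H]1CCCc2cccnc21`), and its sole difference from compound 3 is ethyl in place of 4,4-difluorocyclohexyl on a saturated chain carbon bound to an amine nitrogen with ethyl in place of 4,4-difluorocyclohexyl on a saturated chain carbon bound to an amine nitrogen.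

Among the measured compounds shown here, only one measured step is available, a number 43.4 percentage points lower from compound 1 to compound 2 (beyond the scatter) and it lies on an aromatic carbon, not at the place of the new change. For the measured compounds named here, no measured step therefore gives a size for this change. That step does show that a single change can move this series a long way, so the range stays wide. The expected step is a number 2.6 percentage points lower from compound 3 to compound 4 (within the scatter) and no step beyond the scatter is expected in this assay in either direction. For compound 4 the estimate is 66% (expected range 40% to 92%).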

Compound 4, percent of the compound remaining: 100%
Compound 4: middle estimate off by 34 percentage points, on the low side, outside the stated range (above it).
By their numbers in this assay, from the lowest: compound 2; then compound 3; then compounds 1 and 4 (each within the scatter of the next).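

In this assay the change reads a number 31.4 percentage points higher from compound 3 to compound 4 (beyond the scatter) and so shows that the group on a saturated chain carbon bound to an amine nitrogen can move this read-out a long way, which the earlier step on an aromatic carbon could not show for this position. The change takes away 4,4-difluorocyclohexyl, with its six-membered ring and both fluorines, and puts ethyl in its place; cut one bond further out, propyl replaces (4,4-difluorocyclohexyl)methyl. No available evidence bears on the cause of this step.

The ring and the fluorines leave together, so this single pair cannot tell which of them goes with the step, and plain cyclohexyl at the same place would separate the two. From the compounds shown here alone, how a longer chain such as butyl would read at this position also stays open.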